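A few compounds are considered here, and "the series" means these few. Any claim that something is new, unique, unknown or untested is made for them only; others in the source may bear on it.

Compound 3 `CC(=O)N1CCC(C(=O)N(CCCN2CCN(Cc3cnc(Cl)s3)CC2)c2ccc(C)c(Cl)c2)CC1` stands in an ADME assay (Homo sapiens) for cytotoxicity (a lower number here means that less compound is tolerated, a higher number that more compound is tolerated), only at a limit, > 52300 nM. Compound 1 `CC(=O)N1CCC(C(=O)N(CCCN2CCC(CNC(=O)c3ccsc3)CC2)c2ccc(C)c(Cl)c2)CC1` also gives only a limit in this assay, > 51900 nM. Compound 2 `CC(=O)N1CCC(C(=O)N(CCCN2CCN(Cc3ccc(S(C)(=O)=O)cc3)CC2)c2ccc(C)c(Cl)c2)CC1` likewise gives only a limit, > 49200 nM. For the measured compounds named here, the one step between measured neighbours, a step that the two limits leave unreadable from compound 2 to compound 3, therefore cannot be sized. Compound 4 `CC(=O)N1CCC(C(=O)N(CCCN2CCN(Cc3ccncc3)CC2)c2ccc(C)c(Cl)c2)CC1` differs from compound 3 by pyridin-4-yl in place of 2-chloro-1,3-thiazol-5-yl on a saturated chain carbon bound to an amine nitrogen in a ring. Going by the values given here, every value shown so far sits at a limit, as the limit of > 49200 nM in this assay, at which 1 of the 3 values shown sits, the limit of > 51900 nM in this assay, at which 1 of the 3 values shown sits, and the limit of > 52300 nM in this assay, at which 1 of the 3 values shown sits, record, so no measured step gives a direction for this change. The expected step that the limit leaves unreadable from compound 3 to compound 4 is accordingly none beyond the scatter, with a further limit the most likely outcome. Compound 4 is estimated at 60000 nM in this assay, within a range of 20000 nM to 150000 nM.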

Compound 4, half-maximal cytotoxic concentration: > 56700 nM
Compound 4: only a limit was reported (the forecaster's own chance of this, stated with the estimate: 80%); the middle value lies beyond the limit too.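

Compound 4, like compound 2 and compound 3, gives only a limit in this assay, and the steps between them cannot be read. The compounds shown leave open at what concentration any of them harms cells, and whether exchanging these groups changes it.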